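Cyclobutyl in Place of tert-Butyl at the Amine

This account rests on a few compounds, and the source may have more. Where it says the series, first, only, none or still open, it means among the compounds named here.

Of the compounds shown here, three have been measured in an assay on cells for inhibition of high affinity 3',5'-cyclic-AMP phosphodiesterase 7A (Homo sapiens), read by scintillation counting and cAMP accumulation, with a stated time of 30 min; a lower number here means a stronger inhibitor, a higher number a weaker inhibitor. Compound 1 `CCn1c(NC(C)C)nc2c(C3CCNCC3)csc2c1=O` gives 190 nM, compound 2 `CCn1c(NC(C)(C)C)nc2ccsc2c1=O` gives 1500 nM, and compound 3 `CCn1c(NC(C)C)nc2c(-c3cccnc3)csc2c1=O` gives 4.4 nM. Compound 2 thus stands highest of the three, that is the weakest inhibitor: its nearest neighbour is compound 1, its furthest compound 3, and both gaps lie beyond the scatter. Going by the values given here, only one measured pair differs in a single place, and it shows a 43-fold lower number from compound 1 to compound 3 (1.64 log units; beyond the scatter). That step concerns the substituent on an aromatic carbon and leaves the amine untouched.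

The unmeasured compound 4 `CCn1c(NC2CCC2)nc2ccsc2c1=O` differs from compound 2 by cyclobutyl in place of tert-butyl on a nitrogen on an aromatic ring. Among the compounds with values here, no measured pair isolates a change at this nitrogen; compound 1 and compound 2 differ both at the amine and at the aromatic carbon, so their gap cannot be assigned to either place alone. With nothing in the data bearing directly on the change, the step from compound 2 to compound 4 in this assay is expected to remain within the scatter, as a 1.3-fold lower number from compound 2 to compound 4 (0.10 log units; within the scatter). Compound 4 is therefore estimated at 1200 nM, with a range from 400 nM to 3500 nM.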

Compound 4, half-maximal inhibitory concentration in the high affinity 3',5'-cyclic-AMP phosphodiesterase 7A assay: 300 nM
Compound 4: middle estimate off by 4.0-fold (0.60 log units), on the high side; measured number outside the range, below it.
By their numbers in the high affinity 3',5'-cyclic-AMP phosphodiesterase 7A assay, from the lowest: compound 3; then compounds 1 and 4 (each within the scatter of the next); then compound 2.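

Going by these compounds alone, compound 2 and compound 4 form the first measured pair that isolates the amine, and in the high affinity 3',5'-cyclic-AMP phosphodiesterase 7A assay cyclobutyl in place of tert-butyl on a nitrogen on an aromatic ring gives a 5.0-fold lower number from compound 2 to compound 4 (0.70 log units; beyond the scatter), so the group at this nitrogen alone moves the number beyond the scatter, even though both groups hold 4 heavy atoms, all carbon, and differ in that cyclobutyl carries a four-membered ring. In a physicochemical assay for solubility, in phosphate buffer, at pH 6.8 (a lower number here means a less soluble compound, a higher number a more soluble compound), the same change gives a 1.7-fold higher number from compound 2 to compound 4 (0.23 log units; within the scatter), which lies within the scatter, so compound 2 at 3.7 ug/mL and compound 4 at 6.3 ug/mL cannot be told apart in that measurement. Nothing available accounts for the step at this nitrogen, and its cause stays unknown.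

From the compounds shown here alone, it remains open whether the cyclobutylamino group would bring a step of similar size on a core that also carries pyridin-3-yl or piperidin-4-yl on the aromatic carbon, as compound 3 and compound 1 do. Also open, going by these compounds, is how a cyclopropyl or cyclopentyl group on this nitrogen would read in either measurement, and so whether ring size matters here.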